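From Bromo to Nitro: an Expected Agonist Response

The source may hold more compounds than are shown below. What is called first, only, known or untested is meant among the compounds shown, and "the series" means these compounds.

Three measured compounds share one core and differ only in the group on an aromatic carbon: compound 1 `Nc1scc(-c2cccc(C(F)(F)F)c2)c1C(=O)c1ccc(Cl)cc1` carries trifluoromethyl, compound 2 `Nc1scc(-c2cccc(Cl)c2)c1C(=O)c1ccc(Cl)cc1` chloro and compound 3 `Nc1scc(-c2cccc(Br)c2)c1C(=O)c1ccc(Cl)cc1` bromo. In a functional assay on CHO cells for agonist activity at adenosine receptor A1 (Homo sapiens), read by fluorescence and ERK phosphorylation, with stated times of 30 min and 1.5 h, tested at 10 uM (a higher number here means a stronger effect of the compound at the concentration tested, a lower number a weaker effect), compound 1 gives 73%, compound 2 gives 75% and compound 3 gives 69%. The steps between them, a number 2 percentage points higher from compound 1 to compound 2 (within the scatter), a number 4 percentage points lower from compound 1 to compound 3 (within the scatter) and a number 6 percentage points lower from compound 2 to compound 3 (within the scatter), all lie within the scatter, so none of the three groups can be set apart from the others. Compound 3 holds the lowest of the three numbers, with compound 1 nearest and compound 2 furthest, both within the scatter.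

Compound 4 `Nc1scc(-c2cccc([N+](=O)[O-])c2)c1C(=O)c1ccc(Cl)cc1` is not yet measured; it differs from compound 3 in one place: nitro in place of bromo on an aromatic carbon. Within the data shown here, no step involving nitro exists among the measured compounds, and the steps that bear on the change are the three swaps at this position, each within the scatter. The widening of the group from bromo to a nitro carrying two hydrogen-bond acceptors adds uncertainty, so the expected step of a number 3 percentage points lower from compound 3 to compound 4 (within the scatter) is small and may run either way. Compound 4 is therefore estimated at 66% in this assay, with a range from 48% to 80%.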

Compound 4, a percentage reported as activity, at one concentration (the size of the read-out at that concentration, not a potency): 42%
Estimate against measurement, compound 4: 24 percentage points above; the measured number lies below the stated range.
By their numbers in this assay, from the lowest: compound 4; then compounds 3, 1 and 2 (each within the scatter of the next).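

The flat picture left by the first three compounds does not extend to every group at this place: where the swaps among trifluoromethyl, chloro and bromo stayed within the scatter, nitro brings a number 27 percentage points lower from compound 3 to compound 4 (beyond the scatter) and a number 33 percentage points lower from compound 2 to compound 4 (beyond the scatter) and also a number 31 percentage points lower from compound 1 to compound 4 (beyond the scatter) in this assay at the single concentration tested. Compound 4 is therefore the weakest of the four in this read-out, and it is the only one set apart from all the others, so this position on the six-membered aromatic ring, meta to a large group, does respond to the group it carries. The change itself is known only as bromo leaving and nitro entering, and nothing available here accounts for the lower number.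

From the compounds shown here alone, whether an amine, a nitrile or a carboxylic acid at this place would side with nitro or with the other three groups remains open, so the drop cannot yet be tied to anything broader than nitro itself. It is also open whether nitro would give a similar drop at another carbon of the same ring, since the compounds shown carry each group at this one place only.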